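A few compounds are considered here, and "the series" means these few. Any claim that something is new, unique, unknown or untested is made for them only; others in the source may bear on it.

Measured compounds:

- compound 1 `Cc1cccnc1-c1ccc(C(=O)Nc2ccc(C(C)C)cc2)cc1` gives 73 nM in a functional assay for antagonist activity at transient receptor potential cation channel subfamily V member 1 (Homo sapiens), read by FLIPR; a lower number here means a stronger inhibitor, a higher number a weaker inhibitor
- compound 2 `CC(C)(C)c1ccc(NC(=O)c2ccc(-c3ncccc3NC3CCCC3)cc2)cc1` gives 190 nM in this assay

Compound 2 holds the highest of the two numbers in this assay; its nearest neighbour is compound 1, whose number is lower by a margin beyond the scatter. The two share the same core, and differ in the group on the aromatic carbon two atoms from the ring nitrogen.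

Compound 3 `CC(C)(C)c1ccc(NC(=O)c2ccc(-c3ncccc3-c3nnco3)cc2)cc1` is not yet measured in this assay. It keeps the core of compound 2 and differs from it in one place: 1,3,4-oxadiazol-2-yl in place of cyclopentylamino on an aromatic carbon. Among the measured compounds shown here, no step between measured compounds covers this exchange, so the size of the change is open. With only the two values of compound 1 and compound 2 as context, a small step is expected, in either direction, most likely none beyond the scatter; the expected step is a 1.3-fold lower number from compound 2 to compound 3 (0.10 log units; within the scatter).

For compound 3 the expected value in this assay is 150 nM, within a range of 40 nM to 600 nM.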

Compound 3, half-maximal inhibitory concentration: 91 nM
Compound 3: the middle estimate sits 1.6-fold (0.22 log units) above what was measured; low and high end bracket the measured number.
By their numbers in this assay, from the lowest: compounds 1 and 3 (each within the scatter of the next); then compound 2.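

In this assay the aromatic carbon two atoms from the ring nitrogen tolerates a change of group type: 1,3,4-oxadiazol-2-yl in place of cyclopentylamino gives a 2.1-fold lower number from compound 2 to compound 3 (0.32 log units; beyond the scatter), a modest step. The entering group has no hydrogen-bond donor, so the donor of cyclopentylamino is not required at this position for activity at the level of compound 3. Nothing at hand accounts for the size of this step.

This single exchange alters the ring type, the donor count and the acceptor count together, so it cannot show which of these changes matters. Direct cyclopentyl, phenyl and 1,3-oxazol-2-yl groups at the same place would help separate these features, and the reach of the step beyond this one pair remains open.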